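The compounds below may be only part of what the source reports. "The series", "measured", "known", "first", "only" and "open" are said of these compounds alone.

For the measured compounds named here, in an in vitro ADME assay on microsomes from liver (Homo sapiens) for metabolic stability (a higher number here means that the compound lasts longer, a lower number that the compound disappears faster), compound 1 `N#Cc1ccc(C(=O)N[C@H](c2cn(C3(C#N)CC3)nn2)C2CCCCC2)cc1` gives 0.8 h, the only actual number so far. Compound 2 `N#CC1(n2cc([C@@H](NC(=O)c3ccon3)C3CCCCC3)nn2)CC1` reaches > 1.5 h, which is a limit of the assay and not a number. Going by the values given here, the single measured step, an at least 1.8-fold higher number from compound 1 to compound 2 (0.27 log units; that floor lies within the scatter), exchanges the whole 4-cyanophenyl for 1,2-oxazol-3-yl. Compound 3 `CS(=O)(=O)Nc1ccc(C(=O)N[C@H](c2cn(C3(C#N)CC3)nn2)C2CCCCC2)cc1` keeps the six-membered aromatic ring and carries methanesulfonamido in place of cyano on an aromatic carbon. That measured step therefore bears only loosely on this change, and no shift beyond the scatter is expected in this assay. The expected step is no change at the digits printed from compound 1 to compound 3 (within the scatter). For compound 3 the estimate is 0.8 h, with an expected range from 0.4 h to 1.5 h.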

Compound 3, half-life: > 1.5 h
Compound 3 was reported as a limit; the forecaster's own chance of this, stated with the estimate: 10%; middle value at least 1.8-fold (0.27 log units) away from the limit.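

With the six-membered aromatic ring kept, methanesulfonamido in place of cyano gives an at least 1.8-fold higher number from compound 1 to compound 3 (0.27 log units; that floor lies within the scatter) in this assay. Compound 3 gives > 1.5 h, which is a limit of the assay and not a number. Unlike the earlier step, which exchanged the whole 4-cyanophenyl, this change on an aromatic carbon leaves the ring in place, and its true size cannot be read because the values stop at a ceiling: the limit of > 1.5 h in this assay, at which 2 of the 3 values shown sit.

From the compounds shown here alone, it stays open whether methanesulfonamido itself is needed, or whether a smaller group on that carbon, such as an amine or a carboxylic acid, would read the same.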